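From Hydroxy to Chloro in a Small Series

The source may hold more compounds than are shown below. What is called first, only, known or untested is meant among the compounds shown, and "the series" means these compounds.

In a functional assay on HepG2 cells (Homo sapiens) for cytotoxicity, read by MTT assay, with a stated time of 48 h (on this read-out higher numbers stand for weaker inhibition and lower numbers for stronger inhibition), compound 1 `Cc1ccc(/C=C2/S/C(=N/c3ccccc3)N(Cc3ccncc3)C2=O)cc1` gives 19700 nM, and compound 2 `O=C1/C(=C\c2ccc(O)cc2)S/C(=N/c2ccccc2)N1Cc1ccncc1` gives 11800 nM. Going by the values given here, these two values lie within the scatter of each other, so compound 2 cannot be told apart from the only other measured compound. Compound 3 `O=C1/C(=C\c2ccc(Cl)cc2)S/C(=N/c2ccccc2)N1Cc1ccncc1` has not yet been measured. It carries chloro in place of hydroxy on an aromatic carbon, para to a large group: chloro in place of hydroxy on an aromatic carbon. Among the compounds with values here, one measured step bears on this change: a 1.7-fold lower number from compound 1 to compound 2 (0.22 log units; within the scatter), with hydroxy in place of methyl on an aromatic carbon. Within the data shown here, that step stays within the scatter, and no measured compound here carries chloro, so the evidence is thin. No step beyond the scatter is expected in this assay. The estimate means a 1.2-fold higher number from compound 2 to compound 3 (0.07 log units; within the scatter), which is expected to stay within the scatter. For compound 3 the expected value is 14000 nM, with an estimated range from 6000 nM to 32000 nM.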

Compound 3, half-maximal inhibitory concentration: 28800 nM
Estimate against measurement, compound 3: 2.1-fold (0.31 log units) below; low and high end bracket the measured number.
By their numbers in this assay, from the lowest: compounds 2, 1 and 3 (each within the scatter of the next, the first and the last beyond it).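

Chloro in place of hydroxy at this position, the change from 4-hydroxyphenyl to 4-chlorophenyl, gives the only clear difference in this small series: in this assay there is a 2.4-fold higher number from compound 2 to compound 3 (0.39 log units; beyond the scatter) and this modest move is toward weaker inhibition. Going by these compounds alone, by contrast, a 1.5-fold higher number from compound 1 to compound 3 (0.16 log units; within the scatter) stays within the scatter, so chloro and methyl cannot be told apart here, and the hydroxy and chloro compounds are the only pair that clearly separates. No measurement shown here explains why these two groups differ. The compounds shown leave open where an amine, a carboxylic acid or a methoxy group at this same position would fall relative to compound 2 and compound 3. They also leave open whether the gap between hydroxy and chloro would hold if another part of the shared core were changed.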